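The source may hold more compounds than are shown below. What is called first, only, known or untested is meant among the compounds shown, and "the series" means these compounds.

Two compounds with a shared core have so far been run in a functional assay on MDA-MB-231 cells (Homo sapiens) for inhibition, read by MTT assay, with a stated time of 24 h; on this read-out higher numbers stand for weaker inhibition and lower numbers for stronger inhibition. Compound 1 `CCCCc1cc2ccccc2nc1-c1cc(-c2ccc(F)cc2)no1` gives 24200 nM in this assay. Compound 2 `CCc1cc2ccccc2nc1-c1cc(-c2ccc(C)cc2)no1` stands elsewhere: for compound 2 this assay reports only a limit, > 100000 nM, and no number. Compound 2 thus sits at the limit of > 100000 nM in this assay, at which 1 of the 2 values shown sits, and its true value is not known.

Compound 3 `CCCCc1cc2ccccc2nc1-c1cc(-c2ccc(C)cc2)no1` has not yet been measured. It differs from compound 2 by ethyl in place of hydrogen on a saturated chain carbon, two bonds along the chain from an aromatic carbon. Among the compounds with values here, no measured pair spans this change, so the size of the step from compound 2 to compound 3 cannot be read from a measured step. Compound 1 carries the butyl chain and gives 24200 nM, which is a number rather than a limit. On this basis compound 3 is expected to come in as a number in this assay, with the step of an at least 2.0-fold lower number from compound 2 to compound 3 (0.30 log units; that floor lies within the scatter) expected toward stronger inhibition. For compound 3 the estimate is 50000 nM, with a range from 15000 nM to 150000 nM.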

Compound 3, half-maximal inhibitory concentration: > 100000 nM
Compound 3: a limit, no number (the forecaster's own chance of this, stated with the estimate: 35%); middle value at least 2.0-fold (0.30 log units) away from the limit.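

In this assay compound 3 gives > 100000 nM, which is a limit and not a number, and compound 2 stands at the limit with it: the limit of > 100000 nM in this assay, at which 2 of the 3 values shown sit.

Ethyl in place of hydrogen on the saturated chain carbon, two bonds along the chain from an aromatic carbon, therefore does not bring the methyl-bearing compound to a number, and the size of that step cannot be read. Within the data shown here, with the butyl chain held, methyl in place of fluoro on an aromatic carbon gives an at least 4.1-fold higher number from compound 1 to compound 3 (0.61 log units; beyond the scatter), toward weaker inhibition, and this is the first step that can be read.

On these data alone, the true values of compound 2 and compound 3 remain unknown. As far as these compounds go, it also remains open whether fluoro would still give a number with the ethyl chain, and how a chloro or methoxy group on that aromatic carbon would compare.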